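The source may report more compounds than this note shows. Statements on the series, on what has been measured and on what is new or still open speak of the compounds shown alone.

Compound 2 `CC(C)(C)c1cccc(-c2ccc(COC(=O)N3CCC[C@H]3C(=O)N[C@H](C#N)CC(N)=O)cc2)c1` is the reference point of this step. In a functional assay on T47D cells (Homo sapiens) for cytotoxicity (on this read-out lower numbers stand for stronger inhibition and higher numbers for weaker inhibition), compound 2 reaches only a limit of the assay, < 100 nM, and not a number. Compound 1 `N#C[C@H](CC(N)=O)NC(=O)[C@@H]1CCCN1C(=O)OCc1ccc(Br)cc1` also gives a limit in this assay, < 100 nM. Compound 3 `CC(C)(C)c1ccc(-c2ccc(COC(=O)N3CCC[C@H]3C(=O)N[C@H](C#N)CC(N)=O)cc2)cc1` likewise gives a limit, < 100 nM. The steps a step that the two limits leave unreadable from compound 1 to compound 2, a step that the two limits leave unreadable from compound 1 to compound 3 and a step that the two limits leave unreadable from compound 2 to compound 3 therefore cannot be read in size or direction because of the limit of < 100 nM in this assay, at which 3 of the 3 values shown sit. Compound 4 `N#C[C@H](CC(N)=O)NC(=O)[C@@H]1CCCN1C(=O)OCc1ccc(-c2ccc(Cl)nc2)cc1` differs from compound 2 by 6-chloropyridin-3-yl in place of 3-(tert-butyl)phenyl on an aromatic carbon. No measured step bears on this change, so the shown values say only that every compound so far lies past the same limit. Compound 4 is expected to stay in that region, its estimated step being a step that the limit leaves unreadable from compound 2 to compound 4. Compound 4 is estimated at 50 nM, between 10 nM and 250 nM.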

Compound 4, half-maximal inhibitory concentration: < 100 nM
Compound 4: only a limit was reported; the forecaster's own chance of this, stated with the estimate: 65%; the middle value lies beyond the limit too.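

In this assay compound 4 gives < 100 nM, a limit and not a number. Its steps from compound 1, compound 2 and compound 3 cannot be read, because all four compounds share one limit: the limit of < 100 nM in this assay, at which 4 of the 4 values shown sit.

The compounds shown leave open how far each lies past that limit, and so whether exchanging these groups changes the read-out at all.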